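Side-chain replacement in a purine-based oral analgesic series

The compounds below may be only part of what the source reports. "The series", "measured", "known", "first", "only" and "open" are said of these compounds alone.

Measured compounds:
Compound 1, `CSCC[C@H](NC(=O)CN(c1nc(Cl)nc2[nH]cnc12)C1CC1)C(=O)OCc1ccccc1`: 17.6%
Compound 2, `CSCC[C@H](NC(=O)CN(c1ncnc2c1ncn2C1CCCCO1)C1CC1)C(=O)OCc1ccccc1`: 17.5%
Compound 3, `CSCC[C@H](NC(=O)CN(c1nc(Cl)nc2[nH]cnc12)C1CC1)C(=O)O`: 4.14%

In a functional assay on the whole organism (Tail, strain ICR) with Mus musculus as the target, in the tail flick test, with a stated time of 150 min, at a dose of 25 umol/kg by the oral route (a lower number here means a weaker effect, a higher number a stronger effect of the compound at the dose given), compound 1 gives 17.6% and compound 2 gives 17.5%, the two within the scatter of each other. Among the measured compounds shown here, compound 3 gives 4.14%, and the single step computed in this assay, a number 13.5 percentage points lower from compound 1 to compound 3 (beyond the scatter), concerns the ester end of the molecule only.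

Compound 4, `NC(=O)CC[C@H](NC(=O)CN(c1nc(Cl)nc2[nH]cnc12)C1CC1)C(=O)OCc1ccccc1`, differs from compound 1 at the side chain: carbamoyl in place of methylsulfanyl on a saturated chain carbon, three bonds along the chain from an amide-type nitrogen and a carbonyl carbon. For the measured compounds named here, no measured pair changes this part of the structure, so the step from compound 1 to compound 4 has no direct precedent; the step to compound 3 sits at another position and cannot be carried over. With the shared core and ester kept, the working expectation is a value near that of compound 1, with no step beyond the scatter asserted: a number 2.6 percentage points lower from compound 1 to compound 4 (within the scatter) is the expected change. For compound 4 the estimate in this assay is 15%, ranging from 3% to 30%.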

Compound 4, a percentage reported as activity, at one dose (the size of the read-out at that dose, not a potency): 31.1%
The estimate for compound 4 lay 16.1 percentage points below the measured number; the measured number lies above the stated range.
By their numbers in this assay, from the lowest: compound 3; then compounds 2 and 1 (each within the scatter of the next); then compound 4.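

In this assay the side chain proves to be a position that can move the read-out: carbamoyl in place of methylsulfanyl gives a number 13.5 percentage points higher from compound 1 to compound 4 (beyond the scatter) with the shared core and the benzyl ester unchanged. Among the compounds shown here, the earlier compounds offered a single step, at the ester end and downward, so this is the first step that raises the read-out at the dose given. Nothing available accounts for this gain.

Whether the gain belongs to carbamoyl itself stays open, as a carboxylic acid, an amine or a longer chain at this place is not among the compounds shown. Also open, as far as these compounds go, is whether 2-carbamoylethyl would keep its advantage with hydrogen in place of benzyl at the ester end.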